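The compounds below may be only part of what the source reports. "The series", "measured", "known", "first", "only" and "open" are said of these compounds alone.

Of the compounds shown here, three sharing one core have been tested in a functional assay on WM1361 cells (Homo sapiens) for inhibition, read by MTT assay, with a stated time of 24 h; a higher number here means a weaker inhibitor, a lower number a stronger inhibitor. Compound 1 `O=c1oc2ccccc2c(N2CCN(c3ccccc3F)CC2)c1CO` carries a 2-fluorophenyl group on an amine nitrogen in a ring. Compound 1 reads > 50000 nM, which is a limit of the assay and not a number. Compound 3 `O=c1oc2ccccc2c(N2CCN(c3cccc(C(F)(F)F)c3)CC2)c1CO` also returns only a limit, > 50000 nM. Compound 2 `O=c1oc2ccccc2c(N2CCN(C(c3ccccc3)c3ccc(Cl)cc3)CC2)c1CO` is the only one of the three with a number, 30200 nM. Compound 1 therefore stands at the limit of > 50000 nM in this assay, at which 2 of the 3 values shown sit.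

Compound 4 `COc1ccc(N2CCN(c3c(CO)c(=O)oc4ccccc34)CC2)cc1` has not yet been measured. It has 4-methoxyphenyl in place of 2-fluorophenyl on the same amine nitrogen, and the counted change is 4-methoxyphenyl in place of 2-fluorophenyl on an amine nitrogen in a ring. Among the measured compounds shown here, no two measured compounds differ in one place only, so the data give no direct measure of a swap of this kind. The expectation for compound 4 in this assay rests on the limit reached by compound 1, > 50000 nM. Compound 4 may well return only a limit too. The expected size of the change is a number no higher from compound 1 to compound 4 (the limit leaves the size open). For compound 4 the estimated value is 50000 nM, with an expected range from 25000 nM to 100000 nM.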

Compound 4, half-maximal inhibitory concentration: 40400 nM
Estimate against measurement, compound 4: 1.2-fold (0.09 log units) above; low and high end bracket the measured number.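

With compound 4, the amine nitrogen of the six-membered ring, three ring bonds from the ring nitrogen, gives its first single-place step in this assay: 4-methoxyphenyl in place of 2-fluorophenyl gives an at least 1.2-fold lower number from compound 1 to compound 4 (0.09 log units; that floor lies within the scatter). Among the compounds shown with one six-membered aromatic ring of carbon only on this nitrogen, compound 4 is the only one that returns a number, as compound 4 gives 40400 nM. Compound 1 gives > 50000 nM, which is a limit of the assay and not a number, so the step is only a floor, and limits remain common in this set: the limit of > 50000 nM in this assay, at which 2 of the 4 values shown sit.

The true size of the step therefore stays open, and the swap changes both the group and the printed name's ring number, so the compounds shown do not separate the methoxy group from the loss of fluorine or from where each sits. On these data alone, how a plain phenyl group, or a phenyl ring bearing a carboxylic acid or an amine, would read on this nitrogen also remains open.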